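A Single Chlorine Added to a Glucosidase Inhibitor

The compounds below may be only part of what the source reports. "The series", "measured", "known", "first", "only" and "open" are said of these compounds alone.

Two compounds sharing one core are known so far. Compound 1 `O=C(/C=C(O)/C=C/c1ccc(O)cc1)c1ccccc1O` gives "not determined" (no result reported) in an assay on isolated protein for inhibition of Alpha glucosidase (Homo sapiens), with stated times of 5 min and 15 min (on this read-out lower numbers stand for stronger inhibition and higher numbers for weaker inhibition), so nothing can be said of its potency. Going by the values given here, compound 2 `O=C(/C=C(O)/C=C/c1ccc(O)c(O)c1)c1ccccc1O` is the only compound with a number: in this assay compound 2 gives 14300 nM. Among the compounds with values here, this is the sole measured value. Compound 2 stands alone and can be ranked neither above nor below any other compound here.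

Compound 3 `O=C(/C=C(O)/C=C/c1ccc(O)c(O)c1)c1cc(Cl)ccc1O` has not yet been tested. It differs from compound 2 in a single place, (chloro in place of hydrogen on an aromatic carbon). Within the data shown here, no step between two measured compounds is available, so there is no earlier comparison to lean on. A change of this kind, one heavy atom entering an aromatic ring of the core, is usually expected to move potency only a little, most often within the scatter of repeated measurements or just beyond it, and toward stronger inhibition if anything. The expected step is a 1.4-fold lower number from compound 2 to compound 3 (0.16 log units; within the scatter). Compound 3 is therefore estimated at 10000 nM, with a range from 4000 nM to 30000 nM.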

Compound 3, half-maximal inhibitory concentration: 15100 nM
Compound 3: middle estimate off by 1.5-fold (0.18 log units), on the low side; the measured number falls inside the stated range.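

Placing a chloro group on this aromatic carbon, para to a hydroxy group and meta to a large group, gives a 1.1-fold higher number from compound 2 to compound 3 (0.02 log units; within the scatter) in this assay. Going by these compounds alone, this is the first comparison between two measured compounds that share this core, and it shows that this position can carry a chlorine atom while the two compounds remain indistinguishable on this read-out, with no gain or loss that can be told apart from ordinary repeat-to-repeat variation. Nothing available explains this result or shows how the chlorine atom behaves at this position.

A single substitution cannot show whether this carbon would respond in the same way to an amine, a carboxylic acid or a longer chain, so the tolerance seen here applies only to chloro in place of hydrogen. The step from compound 1 to compound 2 cannot be read because compound 1 has no number, which leaves open what the additional hydroxy group on the other aromatic ring of compound 2 contributes to inhibition.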